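Adding a methoxy group: compound 3 to compound 4

This account rests on a few compounds, and the source may have more. Where it says the series, first, only, none or still open, it means among the compounds named here.

Of the compounds shown here, three have been measured in a functional assay on HT-29 cells (Homo sapiens) for inhibition, read by sulforhodamine B assay, with a stated time of 48 h; a lower number here means a stronger inhibitor of growth, a higher number a weaker inhibitor of growth. Compound 1 `C=C(C)[C@@H]1CC=C(Cn2cc(COc3cc(C4NC(=O)NC(C)=C4C(=O)OCC)ccc3OC)nn2)CC1` gives > 100000 nM, which is a limit of the assay rather than a number (the limit of > 100000 nM in this assay, at which 1 of the 3 values shown sits). Compound 2 `C=C(C)[C@@H]1CC=C(Cn2cc(COc3ccc(C4NC(=O)NC(C)=C4C(C)=O)cc3)nn2)CC1` gives 62600 nM. Compound 3 `C=C(C)[C@@H]1CC=C(Cn2cc(COc3cccc(C4NC(=O)NC5=C4C(=O)CC(C)(C)C5)c3)nn2)CC1` gives 49000 nM; this is the lower of the two numbers shown, and its nearest neighbour is compound 2, whose number lies higher by an amount within the scatter, so the two cannot be put in order. No pair of measured compounds differs in a single place, so no measured step is available, and the expectation for the next compound rests on the shown values and on the structural change alone.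

Compound 4 `C=C(C)[C@@H]1CC=C(Cn2cc(COc3cc(C4NC(=O)NC5=C4C(=O)CC(C)(C)C5)ccc3OC)nn2)CC1` is derived from compound 3 by methoxy in place of hydrogen on an aromatic carbon. The measured numbers sit close to one another and high, and one value of the set is only a limit. On that basis the step is expected to be small, if anything toward a higher concentration, and may not exceed the scatter; the estimated step is a 1.4-fold higher number from compound 3 to compound 4 (0.15 log units; within the scatter). For compound 4 the estimate in this assay is 70000 nM, with a range from 30000 nM to 160000 nM.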

Compound 4, concentration for total growth inhibition: > 100000 nM
Compound 4 was reported as a limit; the forecaster's own chance of this, stated with the estimate: 30%; at least 1.4-fold (0.15 log units) between middle value and limit.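

Methoxy in place of hydrogen on an aromatic carbon, ortho to a large group and para to a large group, is the first change in the series that can be read as a single step, and in this assay it gives an at least 2.0-fold higher number from compound 3 to compound 4 (0.30 log units; that floor lies within the scatter). Compound 4 is reported as > 100000 nM, which is a limit of the assay and not a number. The position therefore shows no gain from methoxy, and the step has only a floor, so its full size cannot be read: the limit of > 100000 nM in this assay, at which 2 of the 4 values shown sit.

On these data alone, whether the true step for methoxy lies beyond the scatter remains open, since a floor within the scatter settles neither its size nor its separation from the scatter. Also open, as far as these compounds go, is how a hydroxyl, a fluorine or an amine on the same aromatic carbon would read in this assay, and whether any of these would bring the number down from the level of the values shown.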